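A smaller chain on the shared core

The source may hold more compounds than are shown below. What is called first, only, known or untested is meant among the compounds shown, and "the series" means these compounds.

Measured so far in a functional assay on MCF7 cells (Homo sapiens) for cytotoxicity, read by MTT assay, with a stated time of 72 h; on this read-out higher numbers stand for weaker inhibition and lower numbers for stronger inhibition:
Compound 1 `C1CCC(c2nnc3nnc(N4CCCC4)nn23)CC1` gives 37700 nM.
Compound 2 `CCCCCc1nnc2nnc(N3CCCC3)nn12` gives 42900 nM.

For the measured compounds named here, compound 2 holds the highest of the two numbers recorded, but its only neighbour, compound 1, lies within the usual scatter of it, so on these numbers the two compounds cannot be told apart.

Compound 3 `CC(C)c1nnc2nnc(N3CCCC3)nn12` has not yet been measured. It differs from compound 2 in one place: isopropyl in place of pentyl on an aromatic carbon. Going by the values given here, only one measured step speaks to this kind of exchange, where one saturated carbon group replaced another at the same place: a 1.1-fold higher number from compound 1 to compound 2 (0.06 log units; within the scatter). That exchange left the read-out essentially where it was.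

Because that single step was a 1.1-fold higher number from compound 1 to compound 2 (0.06 log units; within the scatter), the move to isopropyl is expected to produce no step beyond the scatter, which is the meaning of a 1.0-fold higher number from compound 2 to compound 3 (0.02 log units; within the scatter). Compound 3 is therefore expected to give about 45000 nM, with a plausible range from 20000 nM to 100000 nM.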

Compound 3, half-maximal inhibitory concentration: 46800 nM
For compound 3 the middle estimate is 1.0-fold (0.02 log units) below the measured one, and the stated range covers the measured number.
By their numbers in this assay, from the lowest: compounds 1, 2 and 3 (each within the scatter of the next).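

In this assay, the carbon groups at this place on an aromatic carbon now span a wider range, yet isopropyl in place of pentyl brings no change that can be read (a 1.1-fold higher number from compound 2 to compound 3 (0.04 log units; within the scatter)), and neither does isopropyl in place of cyclohexyl (a 1.2-fold higher number from compound 1 to compound 3 (0.09 log units; within the scatter)). The first pair compared a ring with an open chain; compound 3 adds a smaller, branched group with 3 heavy atoms against the 5 of pentyl, and all three compounds still lie within the scatter of one another, so across these three saturated carbon groups the choice of group leaves the read-out flat. Nothing available here offers a reason for this flatness.

Going by these compounds, it remains open whether a group of another kind at this place, such as a phenyl ring, an amine, a carboxylic acid or a much longer chain like decyl, would move the number beyond the scatter. On these data alone, the other group on the shared core is the same in all three compounds, so what an exchange at that second place would do also stays unknown.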